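Pyridyl to methoxyphenyl on the enone chain: expected potency

This account rests on a few compounds, and the source may have more. Where it says the series, first, only, none or still open, it means among the compounds named here.

Compound 1 `COc1ccc(C(=O)/C=C/c2ccccc2)c2c1C=CC(C)(C)O2`, > 10000 nM (a limit); compound 2 `COc1ccc(/C=C/C(=O)c2ccc(OC)c3c2OC(C)(C)C=C3)cn1`, > 10000 nM (a limit); compound 3 `COc1ccc(C(=O)/C=C/c2ccccn2)c2c1C=CC(C)(C)O2`, 5400 nM.

Among the compounds with values here, in a functional assay on K562 cells (Homo sapiens) for antiproliferative activity, read by MTT assay, with a stated time of 24 h (a lower number here means a stronger inhibitor, a higher number a weaker inhibitor), compound 3 gives the only numerical value. Compound 1 sits at a limit of this assay, > 10000 nM. Compound 2 likewise sits at a limit, > 10000 nM, a point noted in the limit of > 10000 nM in this assay, at which 2 of the 3 values shown sit. Compound 4 `COc1ccccc1/C=C/C(=O)c1ccc(OC)c2c1OC(C)(C)C=C2` differs from compound 3 by 2-methoxyphenyl in place of pyridin-2-yl on a double-bonded chain carbon bound to a double-bonded chain carbon. Within the data shown here, the steps that bear on this change are an at least 1.8-fold lower number from compound 1 to compound 3 (0.26 log units; that floor lies within the scatter) and an at least 1.8-fold lower number from compound 2 to compound 3 (0.26 log units; that floor lies within the scatter), both floors lying within the scatter. Returning to a carbon-only ring is therefore expected to move the number back toward a limit, giving a 1.7-fold higher number from compound 3 to compound 4 (0.22 log units; within the scatter) for compound 4. Compound 4 is estimated at 9000 nM, ranging from 3000 nM to 30000 nM.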

Compound 4, half-maximal inhibitory concentration: > 10000 nM
Compound 4: only a limit was reported; the forecaster's own chance of this, stated with the estimate: 55%; at least 1.1-fold (0.04 log units) between middle value and limit.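

The exchange of pyridin-2-yl for 2-methoxyphenyl on a double-bonded chain carbon bound to a double-bonded chain carbon gives an at least 1.8-fold higher number from compound 3 to compound 4 (0.26 log units; that floor lies within the scatter) in this assay. Compound 4 therefore shows that a methoxy group on the carbon-only ring does not bring a numerical reading. The steps from compound 1 and from compound 2 to compound 4 cannot be read, and compound 3 keeps the only number: the limit of > 10000 nM in this assay, at which 3 of the 4 values shown sit.

From the compounds shown here alone, the actual value of compound 4 stays open. Also open, going by these compounds, is whether pyridin-4-yl or 2-aminophenyl at this place would give a number.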